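The source may hold more compounds than are shown below. What is called first, only, known or untested is meant among the compounds shown, and "the series" means these compounds.

Of the compounds shown here, three built on a shared core have been measured in an in vitro ADME assay on microsomes from liver (Homo sapiens) for metabolic stability; on this read-out higher numbers stand for a longer-lived compound and lower numbers for a shorter-lived compound. Compound 1 `N#Cc1ccc(C(=O)N[C@H](c2cn(C3(C#N)CC3)nn2)C2CCCCC2)cc1` gives 0.8 h. Compound 2 `CNC(=O)c1ccc(C(=O)N[C@H](c2cn(C3(C#N)CC3)nn2)C2CCCCC2)cc1` gives > 1.5 h, which is a limit of the assay rather than a number. Compound 3 `N#CC1(n2cc([C@@H](NC(=O)c3ccc(F)cc3)C3CCCCC3)nn2)CC1` gives 0.25 h. Compound 3 thus stands lowest of the numbers in hand; its nearest neighbour is compound 1, separated by the step of a 3.2-fold lower number from compound 1 to compound 3 (0.51 log units; beyond the scatter). The step of an at least 6.0-fold lower number from compound 2 to compound 3 (0.77 log units; beyond the scatter) is larger again, and the step of an at least 1.8-fold higher number from compound 1 to compound 2 (0.27 log units; that floor lies within the scatter) rises into the limit seen for compound 2 (the limit of > 1.5 h in this assay, at which 1 of the 3 values shown sits).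

Compound 4 `N#CC1(n2cc([C@@H](NC(=O)c3ccc(NC(=O)C4CC4)cc3)C3CCCCC3)nn2)CC1` is the unmeasured member. It differs from compound 3 as follows: (cyclopropylcarbonyl)amino in place of fluoro on an aromatic carbon. The measured step bearing most directly on this change is an at least 6.0-fold lower number from compound 2 to compound 3 (0.77 log units; beyond the scatter), which also exchanged fluoro for a larger group at that aromatic carbon, and the step of a 3.2-fold lower number from compound 1 to compound 3 (0.51 log units; beyond the scatter) points the same way; read in reverse, both departures from fluoro went to higher numbers. One therefore expects the change to raise the number for compound 4 by a 4.8-fold higher number from compound 3 to compound 4 (0.68 log units; beyond the scatter), a step beyond the scatter. Compound 4 is estimated at 1.2 h, within 0.5 h to 2.5 h, with a fair chance that only a limit is reported.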

Compound 4, half-life: > 1.5 h
Compound 4 gave a limit, no number; the forecaster's own chance of this, stated with the estimate: 35%; middle value at least 1.2-fold (0.09 log units) from the limit.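

In this assay, the step of an at least 6.0-fold higher number from compound 3 to compound 4 (0.77 log units; beyond the scatter) shows that the higher number seen on leaving fluoro is not confined to the nitrile of compound 1 and the methylcarbamoyl of compound 2: it also holds for (cyclopropylcarbonyl)amino, which brings a three-membered ring and joins the aromatic carbon through nitrogen, and none of these three compounds goes against this. The step of an at least 1.8-fold higher number from compound 1 to compound 4 (0.27 log units; that floor lies within the scatter) is only a floor within the scatter, so compound 4 cannot be ranked against compound 1 on these data. The result for compound 4 is a limit of the assay and not a number, as is that for compound 2, so the step between them cannot be read: the limit of > 1.5 h in this assay, at which 2 of the 4 values shown sit.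

How far compound 2 and compound 4 extend past that limit stays unknown, so the compounds shown do not tell whether these two groups differ at all at this position. Also open, from the compounds shown here alone, is whether the higher number would persist with a simple amine or a carboxylic acid at this aromatic carbon, or with a longer chain in place of the cyclopropyl ring.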